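The source may hold more compounds than are shown below. What is called first, only, known or untested is meant among the compounds shown, and "the series" means these compounds.

Measured so far:
Compound 1 `C=CCn1c(SCC(=O)Nc2ccc(C(C)=O)cc2)nnc1-c1ccccc1` gives 48%.
Compound 2 `C=CCn1c(SCC(=O)Nc2ccc(/C(C)=N/O)cc2)nnc1-c1ccccc1` gives 61%.
Compound 3 `CCn1c(SCC(=O)Nc2ccc(/C(C)=N/O)cc2)nnc1-c1ccc(OC)c(OC)c1` gives 53%.

All three were tested in a functional assay on the whole organism (strain albino) for inhibition, with Rattus norvegicus as the target, read by paw edema, with stated times of 30 min and 1 h, at a dose of 0.28 mmol/kg by the oral route; on this read-out lower numbers stand for less inhibition and higher numbers for more inhibition at the one dose given (going by the name of the read-out). Compound 2 and compound 1 share one core and differ in one place: a group of 3 heavy atoms (2 carbon, 1 oxygen; no ring) in place of a group of 4 heavy atoms (2 carbon, 1 nitrogen, 1 oxygen; no ring), on an aromatic carbon. That change made the step of a number 13 percentage points lower from compound 2 to compound 1 (beyond the scatter). Compound 3 has a different core; how it differs from compound 2 is not broken down here. Compound 3 and compound 1 lie within the scatter of each other, as do compound 3 and compound 2, so their values alone set no order among them.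

Compound 4 `CCn1c(SCC(=O)Nc2ccc(C(C)=O)cc2)nnc1-c1ccc(OC)c(OC)c1` has not yet been measured in this assay. It stands to compound 3 as compound 1 stands to compound 2: a group of 3 heavy atoms (2 carbon, 1 oxygen; no ring) in place of a group of 4 heavy atoms (2 carbon, 1 nitrogen, 1 oxygen; no ring), on an aromatic carbon. Because the same change made a number 13 percentage points lower from compound 2 to compound 1 (beyond the scatter) on the other core, a step of similar size, a number 13 percentage points lower from compound 3 to compound 4 (beyond the scatter), is expected here, though the step rests on a single earlier pair and the two cores differ. Compound 4 is therefore estimated at 40% in this assay, with a range of 28% to 52% allowing for the scatter of such measurements.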

Compound 4, a percentage reported as inhibition, in the whole organism at one dose (the size of the read-out at that dose, not a potency): 56%
For compound 4 the middle estimate is 16 percentage points below the measured one, and the stated range ends below it.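

On the core of compound 3, acetyl on the aromatic carbon gave a number 3 percentage points higher from compound 3 to compound 4 (within the scatter) in this assay, so the change did not carry over with the size it had on the core of compound 1: the same change on two cores in this assay, a number 13 percentage points lower (beyond the scatter) from compound 2 to compound 1 and a number 3 percentage points higher (within the scatter) from compound 3 to compound 4, 16 percentage points apart, beyond the scatter of two such steps

In this assay, at this one dose, the effect of the change therefore depends on the core, and the loss seen on one core cannot be assumed on the other. The two pairs do not show which difference between the cores matters, as these cores differ in more than one place, and two pairs cannot establish a general rule for the series.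

The compounds shown leave open how the change behaves on a core that differs from that of compound 1 in only one place. They also leave open what other groups on this aromatic carbon, such as an amine or a carboxylic acid, would give on either core.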